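Anilide to pyrrolidine amide on a shared cytotoxicity core

This account rests on a few compounds, and the source may have more. Where it says the series, first, only, none or still open, it means among the compounds named here.

Compound 1 `O=C(Nc1ccc(OC(F)F)cc1)c1cccc(/C=C2\CC(=O)N(c3ccccc3)C2=O)c1` and compound 2 `O=C(Nc1cccc(F)c1)c1cccc(/C=C2\CC(=O)N(c3ccccc3)C2=O)c1` share one core and differ only in the group on the amide-type nitrogen. In an ADME assay on SW480 cells (Homo sapiens) for cytotoxicity, read by MTT assay, with a stated time of 72 h (a higher number here means a weaker inhibitor, a lower number a stronger inhibitor), compound 1 reaches only the limit of the assay, > 100000 nM. In this assay compound 2 likewise reaches only the limit, > 100000 nM. The step between them is therefore unreadable: a step that the two limits leave unreadable from compound 1 to compound 2. Both values sit at the limit of > 100000 nM in this assay, at which 2 of the 2 values shown sit, so compound 2 stands at the ceiling of what this assay reports.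

Compound 3 `O=C(c1cccc(/C=C2\CC(=O)N(c3ccccc3)C2=O)c1)N1CCCC1` carries pyrrolidin-1-yl in place of (3-fluorophenyl)amino on a carbonyl carbon. No readable measured step bears on this change, since the only step shown is unreadable and the two values give no direction. The estimate for compound 3 is a step of a number no higher from compound 2 to compound 3 (the limit leaves the size open), with no movement beyond the scatter expected. Compound 3 is thus expected to give 100000 nM in this assay, within a range from 30000 nM to 300000 nM.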

Compound 3, half-maximal inhibitory concentration: > 100000 nM
Compound 3: only a limit was reported; the forecaster's own chance of this, stated with the estimate: 75%; the middle value lies on the limit itself.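

In this assay compound 3 gives only a limit of the assay, > 100000 nM. The steps to compound 3 from compound 1 and compound 2 therefore cannot be read. The compounds shown leave open whether changing the group on the carbonyl carbon alters the value at all: the limit of > 100000 nM in this assay, at which 3 of the 3 values shown sit.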